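Exchanging chloro for methoxy in a cytotoxic series

The source may report more compounds than this note shows. Statements on the series, on what has been measured and on what is new or still open speak of the compounds shown alone.

In a functional assay on MCF7 cells (Homo sapiens) for cytotoxicity, read by MTT assay, with a stated time of 72 h (on this read-out lower numbers stand for stronger inhibition and higher numbers for weaker inhibition), compound 1 `COc1cccc(/C=C2\CCC/C(=C\c3ccccc3Cl)C2=O)c1OC` gives 11300 nM and compound 3 `COc1ccc(/C=C2\CCC/C(=C\c3cccc(Cl)c3)C2=O)cc1OC` gives 6000 nM, two values within the scatter of each other. Compound 2 `COc1cccc(/C=C2\CCC/C(=C\c3cccc(Cl)c3Cl)C2=O)c1OC` gives > 20000 nM, which is a limit of the assay and not a number.

Compound 4 `COc1cccc(/C=C2\CCC/C(=C\c3ccc(OC)c(OC)c3)C2=O)c1` differs from compound 3 by methoxy in place of chloro on an aromatic carbon, meta to a large group. For the measured compounds named here, the only measured step is a different change, chloro in place of hydrogen on an aromatic carbon, and it reads an at least 1.7-fold higher number from compound 1 to compound 2 (0.24 log units; that floor lies within the scatter). Going by the values given here, that step rests on (the limit of > 20000 nM in this assay, at which 1 of the 3 values shown sits), and no measured pair shows chloro exchanged for methoxy. Compound 3, at 6000 nM, therefore remains the anchor, and no step beyond the scatter is expected in this assay. The estimated change is a 1.3-fold higher number from compound 3 to compound 4 (0.12 log units; within the scatter), a small expected move toward weaker inhibition. For compound 4 the estimate is 8000 nM, with an expected range of 3000 nM to 20000 nM.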

Compound 4, half-maximal inhibitory concentration: 4600 nM
Estimate against measurement, compound 4: 1.7-fold (0.24 log units) above, within the range that was stated.
By their numbers in this assay, from the lowest: compounds 4, 3 and 1 (each within the scatter of the next, the first and the last beyond it). At a limit, above all of these: compound 2.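

In this assay, for the compounds shown here, going from 3-chlorophenyl to 3-methoxyphenyl gives a 1.3-fold lower number from compound 3 to compound 4 (0.12 log units; within the scatter), and this is the only measured pair that sets chloro against methoxy on this aromatic carbon, meta to a large group. At this position, then, a methoxy, which has one more heavy atom than chloro and brings in a hydrogen-bond acceptor, produces no step beyond the scatter, something the earlier step of chloro in place of hydrogen could not show. Nothing given here points to a cause for this result.

From the compounds shown here alone, whether an amine, a carboxylic acid or a longer chain such as ethoxy at this place would also stay within the scatter remains open. The compounds shown also leave open how the same exchange would read elsewhere on the shared core.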